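The source may hold more compounds than are shown below. What is called first, only, known or untested is meant among the compounds shown, and "the series" means these compounds.

Measured compounds:
compound 1 `COc1cccc(-n2cc(COC(=O)/C(C)=C/CC/C(C)=C/CC/C(C)=C/CC[C@@H]3[C@@]4(C)CCC(=O)C(C)(C)[C@H]4CC[C@@]3(C)O)nn2)c1` — > 150000 nM
compound 2 `C/C(=C\CC/C(C)=C/CC[C@@H]1[C@@]2(C)CCC(=O)C(C)(C)[C@H]2CC[C@@]1(C)O)CC/C=C(\C)C(=O)OCc1cn(C[C@@H]2O[C@H](n3ccc(=O)[nH]c3=O)C[C@H]2O)nn1` — 33100 nM

In a functional assay on DU-145 cells (Homo sapiens) for antiproliferative activity, read by MTT assay, with a stated time of 48 h (on this read-out higher numbers stand for weaker inhibition and lower numbers for stronger inhibition), compound 1 gives > 150000 nM, which is a limit of the assay and not a number. In this assay compound 2 gives 33100 nM. Compound 1 therefore stands only at the limit of > 150000 nM in this assay, at which 1 of the 2 values shown sits, the weak end of what is known. Compound 3 `COc1ccc(-n2cc(COC(=O)/C(C)=C/CC/C(C)=C/CC/C(C)=C/CC[C@@H]3[C@@]4(C)CCC(=O)C(C)(C)[C@H]4CC[C@@]3(C)O)nn2)cc1` differs from compound 1 by 4-methoxyphenyl in place of 3-methoxyphenyl on an aromatic nitrogen. Within the data shown here, no measured step covers such a change, so nothing beyond the scatter is expected; the expected step is an at least 1.2-fold lower number from compound 1 to compound 3 (0.09 log units; that floor lies within the scatter). Compound 3 is estimated at 120000 nM, between 40000 nM and 300000 nM, and may again appear only as a limit.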

Compound 3, half-maximal inhibitory concentration: 135000 nM
Beside the measured number, compound 3's estimate is 1.1-fold (0.05 log units) below it; the range from low to high includes it.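

With 4-methoxyphenyl in place of 3-methoxyphenyl on the aromatic nitrogen, this assay shows an at least 1.1-fold lower number from compound 1 to compound 3 (0.04 log units; that floor lies within the scatter), a floor within the usual scatter, so this change separates the two groups by no measurable margin. For a methoxyphenyl on this nitrogen, compound 3 provides the first actual number, 135000 nM. Compound 1 remains a limit of the assay and not a number: the limit of > 150000 nM in this assay, at which 1 of the 3 values shown sits.

The compounds shown leave open how an amine or a carboxylic acid in place of the methoxy group on this phenyl would read in this assay.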